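A Chlorine Shifted on the Benzyl Group

The source may hold more compounds than are shown below. What is called first, only, known or untested is meant among the compounds shown, and "the series" means these compounds.

Compound 1 `CSCC[C@H](NC(=O)c1ccc(NCc2cncn2Cc2ccc(C#N)cc2)cc1-c1ccccc1)C(=O)O` gives > 10 uM in a functional assay on NIH3T3 cells (Mus musculus) (on this read-out higher numbers stand for an effect only at larger amounts of compound and lower numbers for an effect already at smaller amounts), which is a limit of the assay and not a number.
Compound 2 `COC(=O)[C@H](CCSC)NC(=O)c1ccc(NCc2cncn2Cc2ccc(Cl)cc2)cc1-c1ccccc1` gives > 10 uM in this assay, again a limit.
Compound 3 `COC(=O)[C@H](CCSC)NC(=O)c1ccc(CN(Cc2c[nH]cn2)Cc2c[nH]cn2)cc1-c1ccccc1C` gives > 10 uM in this assay, again a limit.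

Compound 2 therefore stands where every measured compound stands: at the limit of > 10 uM in this assay, at which 3 of the 3 values shown sit. For the measured compounds named here, no two measured compounds differ in only one place, so no step between measured values can be read off, and nothing here separates the three from one another.

Compound 4 `COC(=O)[C@H](CCSC)NC(=O)c1ccc(NCc2cncn2Cc2ccccc2Cl)cc1-c1ccccc1` has not been measured. It differs from compound 2 by 2-chlorophenyl in place of 4-chlorophenyl on a saturated chain carbon bound to an aromatic nitrogen. The same atoms are present, only joined differently. With every measured value sitting at the limit, the change from compound 2 to compound 4 is expected to give no step beyond the usual scatter, and compound 4 is expected most likely to return a limit as well. My estimate for compound 4 in this assay is 15 uM, within 4 uM to 60 uM, meaning an expected step that the limit leaves unreadable from compound 2 to compound 4.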

Compound 4, concentration for half-maximal effect: > 10 uM
Compound 4: only a limit was reported; the forecaster's own chance of this, stated with the estimate: 75%; the middle value lies beyond the limit too.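

In this assay, for the compounds shown here, compound 2 and compound 4 each give only a limit and not a number, and no step between them can be read. Left open is whether 4-chlorobenzyl and 2-chlorobenzyl differ at all, and at what amount any of the four compounds would show an effect.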